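Hydrogen to trifluoromethyl: what compound 4 may show

The source may report more compounds than this note shows. Statements on the series, on what has been measured and on what is new or still open speak of the compounds shown alone.

Compound 1 `Cc1cn(/C=C/C=O)c(=O)[nH]c1=O` gives 25000 nM
Compound 2 `Nc1nc(O)c2ncn(/C=C/C=O)c2n1` gives > 100000 nM (a limit of the assay)
Compound 3 `O=C/C=C/n1ccc(=O)[nH]c1=O` gives 30000 nM

In a functional assay on HeLa cells (Homo sapiens) for inhibition (a lower number here means a stronger inhibitor, a higher number a weaker inhibitor), compound 3 (30000 nM) lies within the scatter of compound 1 (25000 nM), so the two cannot be ranked. The entry for compound 2 (> 100000 nM) is a limit of the assay, not a number.

Compound 4 `O=C/C=C/n1cc(C(F)(F)F)c(=O)[nH]c1=O` has not yet been measured. It differs from compound 3 by trifluoromethyl in place of hydrogen on an aromatic carbon.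

Among the compounds with values here, one measured step bears on this change, since it concerns the same aromatic carbon: a 1.2-fold higher number from compound 1 to compound 3 (0.08 log units; within the scatter), with hydrogen in place of methyl. That step stays within the scatter, but a single step involving methyl says little about trifluoromethyl, so the expectation remains loose. No step beyond the scatter is therefore expected in this assay, although a shift in either direction cannot be excluded. The expected change is a 1.2-fold lower number from compound 3 to compound 4 (0.08 log units; within the scatter) and is only an estimate. The estimated value for compound 4 is 25000 nM with an expected range of 8000 nM to 70000 nM in this assay.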

Compound 4, half-maximal inhibitory concentration: 80000 nM
Compound 4: the middle estimate sits 3.2-fold (0.51 log units) below what was measured; the whole stated range lies below it.
By their numbers in this assay, from the lowest: compounds 1 and 3 (each within the scatter of the next); then compound 4. At a limit, above all of these: compound 2.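

In this assay, within the data shown here, the earlier pair at this aromatic carbon, hydrogen and methyl, could not be ranked, whereas trifluoromethyl gives the first steps here that lie beyond the scatter, with a 2.7-fold higher number from compound 3 to compound 4 (0.43 log units; beyond the scatter) and with a 3.2-fold higher number from compound 1 to compound 4 (0.51 log units; beyond the scatter) as the matching comparison against methyl. Both steps are modest and both point towards a weaker inhibitor, so this position does respond to what it carries, and trifluoromethyl reads differently from both hydrogen and methyl on the same core. Nothing among the data shown gives a cause for this rise.

As far as these compounds go, it remains open whether the loss belongs to trifluoromethyl in particular or would extend to other groups on this aromatic carbon, such as a chlorine atom, an ethyl group, an amine or a nitrile. The 2-formylethenyl group is also the same in compound 1, compound 3 and compound 4, so how a saturated chain or a carboxylic acid in its place would read in this assay, with either hydrogen or trifluoromethyl on the aromatic carbon, stays unanswered.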